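Swapping the amine substituent: what to expect of compound 4

The compounds below may be only part of what the source reports. "The series", "measured", "known", "first", "only" and "open" are said of these compounds alone.

Of the compounds shown here, three built on one shared core have been measured in a functional assay on CHO cells for activation of 5-hydroxytryptamine receptor 1D (Homo sapiens), read by GTPgammaS binding; on this read-out higher numbers stand for larger maximal responses and lower numbers for smaller maximal responses. Compound 1 `OCCC(NC1CCN(CCCc2c[nH]c3ccc(-n4cnnc4)cc23)CC1)c1ccccc1` gives 100%. Compound 2 `CC(C)=CCN(C)C1CCN(CCCc2c[nH]c3ccc(-n4cnnc4)cc23)CC1` gives 115%, and compound 3 `CN(Cc1ccsc1)C1CCN(CCCc2c[nH]c3ccc(-n4cnnc4)cc23)CC1` gives 93%. Among these three numbers compound 3 stands lowest: the nearest is that of compound 1, with a number 7 percentage points lower from compound 1 to compound 3 (within the scatter), and the furthest is that of compound 2, with a number 22 percentage points lower from compound 2 to compound 3 (beyond the scatter). Compound 4 `CC(CO)(NC1CCN(CCCc2c[nH]c3ccc(-n4cnnc4)cc23)CC1)c1ccccc1` has not yet been measured in this assay. It differs from compound 3 at a single place: (1-(hydroxymethyl)-1-phenylethyl)amino in place of methyl((thiophen-3-yl)methyl)amino on a saturated ring carbon. The entering group resembles the (3-hydroxy-1-phenylpropyl)amino group of compound 1 in carrying one six-membered aromatic ring of carbon only and 2 hydrogen-bond donors, so the step that bears most on this change is a number 7 percentage points lower from compound 1 to compound 3 (within the scatter), which stayed within the scatter, while a number 15 percentage points higher from compound 1 to compound 2 (beyond the scatter) shows that a change at this position can shift the number modestly. A return to roughly the number of compound 1 is therefore expected. Compound 4 is expected to give 100%, within 85% to 118%. The expected step is a number 7 percentage points higher from compound 3 to compound 4 (within the scatter).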

Compound 4, largest response reached (reported as efficacy), in percent of the reference or control that the assay uses: 59%
Compound 4: middle estimate off by 41 percentage points, on the high side; measured number outside the range, below it.
By their numbers in this assay, from the lowest: compound 4; then compounds 3 and 1 (each within the scatter of the next); then compound 2.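

The step of a number 41 percentage points lower from compound 1 to compound 4 (beyond the scatter) is the telling one: 1-(hydroxymethyl)-1-phenylethyl and 3-hydroxy-1-phenylpropyl sit on the same amine nitrogen and share one six-membered aromatic ring of carbon only, yet they do not give a like number in this assay. For the compounds shown here, with a number 34 percentage points lower from compound 3 to compound 4 (beyond the scatter) and a number 56 percentage points lower from compound 2 to compound 4 (beyond the scatter), this position proves able to move the maximal response by far more than the earlier steps showed, and a shared ring type and donor count do not carry the number over from one group to the other. Nothing available here accounts for this drop.

Going by these compounds, it remains open whether a 2-hydroxy-1-phenylethyl group or a plain 1-phenylethyl group on that nitrogen would stay near compound 1 or near compound 4. Also open, on these data alone, is what a methyl group on the amine nitrogen of compound 4 would do to the number.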